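The compounds below may be only part of what the source reports. "The series", "measured", "known", "first", "only" and "open" are said of these compounds alone.

Compound 2 `NS(=O)(=O)c1ccc(NC(=S)Nc2ccc3ncnc(Nc4ccc(C(F)(F)F)cc4)c3c2)cc1` and compound 1 `NS(=O)(=O)c1ccc(NC(=S)Nc2ccc3ncnc(Nc4ccc(F)c(Cl)c4)c3c2)cc1` share one core and differ only in the group carried on a nitrogen on an aromatic ring. Among the compounds with values here, in a functional assay on A-431 cells (Homo sapiens) for antiproliferative activity, read by MTT assay, with a stated time of 72 h (a lower number here means a stronger inhibitor, a higher number a weaker inhibitor), compound 1 gives 37600 nM, and in this assay compound 2 gives 18000 nM, so compound 2 holds the lowest of the two numbers measured so far, with compound 1 as its only neighbour.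

The step now followed leads from compound 2 to compound 3 `NS(=O)(=O)c1ccc(NC(=S)Nc2ccc3ncnc(Nc4cccc(F)c4)c3c2)cc1`. The change is 3-fluorophenyl in place of 4-(trifluoromethyl)phenyl on a nitrogen on an aromatic ring. Within the data shown here, only one measured step bears on it: a 2.1-fold lower number from compound 1 to compound 2 (0.32 log units; beyond the scatter), a swap of the aryl group at the same nitrogen. That step was modest in size, and both measured numbers lie in a weak range. Accordingly, compound 3 is expected to move by no more than a modest step in this assay, with the direction uncertain, most likely staying within the neighbourhood of compound 2; the expected step is a 1.4-fold higher number from compound 2 to compound 3 (0.14 log units; within the scatter). In this assay compound 3 is therefore estimated at 25000 nM, with a range from 8000 nM to 70000 nM.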

Compound 3, half-maximal inhibitory concentration: 30100 nM
For compound 3 the middle estimate is 1.2-fold (0.08 log units) below the measured one; the range from low to high includes it.
By their numbers in this assay, from the lowest: compounds 2, 3 and 1 (each within the scatter of the next, the first and the last beyond it).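

In this assay, 3-fluorophenyl in place of 3-chloro-4-fluorophenyl on the nitrogen gives one reading (a 1.2-fold lower number from compound 1 to compound 3 (0.10 log units; within the scatter)), and 3-fluorophenyl in place of 4-(trifluoromethyl)phenyl gives another (a 1.7-fold higher number from compound 2 to compound 3 (0.22 log units; within the scatter)). Within the data shown here, compound 3 therefore cannot be told apart from either of its neighbours, and the only separation beyond the scatter remains the one between compound 1 and compound 2. All three aryl groups, with chlorine and fluorine, fluorine alone, or trifluoromethyl, leave the numbers in one weak range, running from compound 2 (18000 nM) to compound 1 (37600 nM). Nothing measured here offers an explanation for these numbers.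

On these data alone, whether an amine, a carboxylic acid or a methoxy group on this phenyl ring, or a longer chain in place of the ring, would move the number beyond the scatter stays open. All three compounds keep the shared core, so they say nothing about what a change elsewhere in the molecule would do.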